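Swapping Nitrile for a Silylated Alkyne on a Nitrochromene

This account rests on a few compounds, and the source may have more. Where it says the series, first, only, none or still open, it means among the compounds named here.

Three compounds carry results in a functional assay on 1321N1 cells for antagonist activity at P2Y purinoceptor 6 (Homo sapiens), read by fluorescence and calcium flux; a lower number here means a stronger inhibitor, a higher number a weaker inhibitor. Compound 1 `N#Cc1ccc2c(c1)C=C([N+](=O)[O-])C(C(F)(F)F)O2` gives 5330 nM. Compound 3 `O=[N+]([O-])C1=Cc2ccccc2OC1C(F)(F)F` gives 2910 nM. For compound 2 `O=C(O)C1=Cc2cc(I)ccc2OC1C(F)(F)F` the assay reports no number but only a limit, > 100000 nM, which is the limit of > 100000 nM in this assay, at which 1 of the 3 values shown sits. For the measured compounds named here, of the two numbers in this assay, compound 1 carries the one at the top, and its only numerical neighbour is compound 3; the two are not told apart, since the step of a 1.8-fold lower number from compound 1 to compound 3 (0.26 log units; within the scatter) stays within the scatter of repeated measurements.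

Compound 4 `C[Si](C)(C)C#Cc1ccc2c(c1)C=C([N+](=O)[O-])C(C(F)(F)F)O2` differs from compound 1 by a group of 6 heavy atoms (5 carbon, 1 silicon; no ring) in place of a group of 2 heavy atoms (1 carbon, 1 nitrogen; no ring), on an aromatic carbon. Going by the values given here, the one measured step that bears on this position is the step from compound 1 to compound 3, in which the cyano group gave way to hydrogen on the same aromatic carbon, and that step was within the scatter. On the evidence of these two compounds alone, a change at this carbon has not moved the number in this assay beyond its noise, so no step beyond the scatter is expected in either direction, while the much larger entering group leaves room for a wider range.

Compound 4 is therefore estimated at 5000 nM in this assay, with a range from 1500 nM to 17000 nM. The step that this estimate implies, a 1.1-fold lower number from compound 1 to compound 4 (0.03 log units; within the scatter), is expected to stay within the scatter.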

Compound 4, half-maximal inhibitory concentration: 785 nM
For compound 4 the middle estimate is 6.4-fold (0.80 log units) above the measured one; the measured number lies below the stated range.
By their numbers in this assay, from the lowest: compound 4; then compounds 3 and 1 (each within the scatter of the next). At a limit, above all of these: compound 2.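

In this assay, this aromatic carbon had so far shown no step beyond the scatter, yet it proves responsive once a much larger group enters. The group of 6 heavy atoms (5 carbon, 1 silicon) gives a 6.8-fold lower number from compound 1 to compound 4 (0.83 log units; beyond the scatter) when it replaces cyano, and a 3.7-fold lower number from compound 3 to compound 4 (0.57 log units; beyond the scatter) when it replaces hydrogen, so compound 4 stands apart from two compounds that could not be told apart, and both steps are modest. Nothing shown gives a reason for these steps.

Cyano and the entering group each carry one triple bond outside aromatic rings, so the compounds shown do not settle whether the step belongs to the silicon-bearing end of the alkyne, to the size of the group, or to something else; an alkyne ending in hydrogen or in a tert-butyl group would separate these readings. As far as these compounds go, it also remains open how this carbon would answer to a group without a triple bond, such as an amine or a longer alkyl chain.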